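The source may hold more compounds than are shown below. What is called first, only, known or untested is meant among the compounds shown, and "the series" means these compounds.

Measured so far:
compound 1 `COc1cc(/C=C/C(=O)/C=C(O)/C=C/c2ccc(OC(=O)[C@@H](CCSC)NC(=O)OCc3ccccc3)c(OC)c2)ccc1OC(=O)[C@@H](CCSC)NC(=O)OCc1ccccc1`: 79%
compound 2 `COc1cc(/C=C/C(=O)/C=C(O)/C=C/c2ccc(OC(=O)[C@H](C)NC(=O)OC(C)(C)C)c(OC)c2)ccc1OC(=O)[C@H](C)NC(=O)OC(C)(C)C`: 6%

In a functional assay on the whole organism (strain Wistar) for inhibition, with Rattus norvegicus as the target, read by paw edema, with a stated time of 1 h, at a dose of 10 mg/kg by the intraperitoneal route (on this read-out lower numbers stand for less inhibition and higher numbers for more inhibition at the one dose given (going by the name of the read-out)), compound 1 gives 79%, while compound 2 gives 6%. Compound 2 stands at the lower of the two numbers, and its gap to compound 1 lies beyond the usual scatter. Within the data shown here, no single-change step between the two measured compounds is known, so their two values show only that they differ.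

Among the measured compounds shown here, compound 3 `COc1cc(/C=C/C(=O)/C=C(O)/C=C/c2ccc(OC(=O)[C@@H](C)NC(=O)OC(C)(C)C)c(OC)c2)ccc1OC(=O)[C@@H](C)NC(=O)OC(C)(C)C` has not yet been measured in this assay. the two compounds have the same atoms and bonds and differ only in configuration as drawn: 2 of 5 stereo elements differ; a stereocentre at a saturated chain carbon is drawn S in compound 2 and R in compound 3; a stereocentre at a saturated chain carbon is drawn S in compound 2 and R in compound 3 The only measured pair, compound 1 against compound 2, changes several groups at once and says nothing about configuration on its own. For compound 3 the expected step is a number 6 percentage points higher from compound 2 to compound 3 (within the scatter), a shift that is expected to stay within the scatter, with no direction favoured. Compound 3 is therefore estimated at 12%, with a range from 0% to 40%.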

Compound 3, a percentage reported as inhibition, in the whole organism at one dose (the size of the read-out at that dose, not a potency): 22%
The estimate for compound 3 lay 10 percentage points below the measured number, and the stated range covers the measured number.
By their numbers in this assay, from the lowest: compound 2; then compound 3; then compound 1.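

In this assay, inverting the configuration gives a number 16 percentage points higher from compound 2 to compound 3 (beyond the scatter). Among these compounds, this is the first measured comparison that isolates a single kind of change, showing that the drawn configuration of the two saturated chain stereocentres can by itself shift this whole-animal read-out. The shift can be tied to configuration rather than to a change of groups because nothing else separates the pair: the fact that compounds 2 and 3 differ only in the configuration as drawn

From the compounds shown here alone, both stereocentres change together, so the contribution of each one remains unknown, as does the result for a compound carrying one centre drawn S and the other drawn R. It also remains open whether configuration would matter in the same direction or to the same extent with a free amine in place of each carbamate.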